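The source may hold more compounds than are shown below. What is called first, only, known or untested is meant among the compounds shown, and "the series" means these compounds.

Compound 1 `COc1cccc2c1CCC2c1ncc[nH]1` gives > 10000 nM in a functional assay on CHO cells for agonist activity at Alpha-1B adrenergic receptor (Homo sapiens), read by FLIPR and calcium flux (on this read-out higher numbers stand for an effect only at larger amounts of compound and lower numbers for an effect already at smaller amounts), a limit of the assay.
Compound 2 `c1ccc2c(c1)CCC2c1ncc[nH]1` gives > 10000 nM in this assay, likewise a limit.

Compound 2 therefore stands only at the limit of this assay, with no number. Going by the values given here, the one measured step, a step that the two limits leave unreadable from compound 1 to compound 2, stays unreadable because of the limit of > 10000 nM in this assay, at which 2 of the 2 values shown sit. Compound 3 `CS(=O)(=O)Nc1cccc2c1CCC2c1ncc[nH]1` differs from compound 2 by methanesulfonamido in place of hydrogen on an aromatic carbon. Among the compounds with values here, no measured step bears on this change, so nothing beyond the limit is expected. Compound 3 is estimated to give 10000 nM in this assay, within 3000 nM to 30000 nM. The expected step is then a number no higher from compound 2 to compound 3 (the limit leaves the size open).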

Compound 3, half-maximal effective concentration: > 10000 nM
Compound 3: a limit, no number; the forecaster's own chance of this, stated with the estimate: 75%; the middle value lies on the limit itself.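

Compound 3 yields no readable step against compound 2 or compound 1, because all three compounds stand at a limit, not a number: the limit of > 10000 nM in this assay, at which 3 of the 3 values shown sit.

The compounds shown leave open whether methoxy, hydrogen or methanesulfonamido on the aromatic carbon changes the result in this assay.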